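Ethyl to isopropyl ester on a dihydropyrimidine scaffold

The compounds below may be only part of what the source reports. "The series", "measured", "known", "first", "only" and "open" are said of these compounds alone.

Of the compounds shown here, two sharing one core have been measured in an assay on HEK293 cells for displacement of a labelled ligand from adenosine receptor A2b (Homo sapiens), with a stated time of 30 min; on this read-out lower numbers stand for stronger inhibition and higher numbers for weaker inhibition. Compound 1 `CC1=C(C(=O)OC(C)C)[C@@H](c2ccco2)N/C(=N/C#N)N1` gives 15.1 nM, while compound 2 `CCOC(=O)C1=C(C)N/C(=N\C#N)NC1c1ccco1` gives 900 nM, the higher of the two numbers, and the gap from compound 1 lies beyond the scatter. Compound 3 `CC1=C(C(=O)OC(C)C)C(c2ccco2)N/C(=N/C#N)N1` differs from compound 2 only by methyl in place of hydrogen on a saturated chain carbon bound to an oxygen next to a carbonyl group and a saturated chain carbon. Among the compounds with values here, no measured step reports that change directly; the estimate leans on compound 1 with its 15.1 nM, which carries the isopropyl ester, so a sizable decrease is expected. Compound 3 is estimated at 40 nM, within 10 nM to 200 nM, meaning an expected step of a 23-fold lower number from compound 2 to compound 3 (1.35 log units; beyond the scatter) in this assay.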

Compound 3, inhibition constant: 24.3 nM
The estimate for compound 3 lay 1.6-fold (0.22 log units) above the measured number, within the range that was stated.
By their numbers in this assay, from the lowest: compounds 1 and 3 (each within the scatter of the next); then compound 2.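

In this assay the change from ethoxycarbonyl to isopropoxycarbonyl now stands alone as a 37-fold lower number from compound 2 to compound 3 (1.57 log units; beyond the scatter), so a single methyl on this saturated chain carbon accounts for a large step. Compound 1 and compound 3 stay within the scatter of each other, at a 1.6-fold higher number from compound 1 to compound 3 (0.21 log units; within the scatter). That pair differs in one respect only: the fact that one of compounds 1 and 3 is drawn with a defined configuration and the other without, at the place where they differ.

On these data alone, whether a longer chain or a tert-butyl ester would go further along this step stays open. So does the reading of the opposite configuration at that saturated ring carbon, drawn on its own.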